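A few compounds are considered here, and "the series" means these few. Any claim that something is new, unique, unknown or untested is made for them only; others in the source may bear on it.

Two compounds share a core and differ only in the group on the amine nitrogen of the six-membered ring with two nitrogens. Compound 1 `S=c1oc(-c2ccc3c(c2)OCCO3)nn1CN1CCN(C(c2ccccc2)c2ccccc2)CC1` carries a diphenylmethyl group there; in a functional assay on HepG2 cells (Homo sapiens) for antiproliferative activity, read by MTT assay, with a stated time of 48 h (on this read-out higher numbers stand for weaker inhibition and lower numbers for stronger inhibition), compound 1 gives 9120 nM. Compound 2 `Cc1ccc(N2CCN(Cn3nc(-c4ccc5c(c4)OCCO5)oc3=S)CC2)c(C)c1` carries a 2,4-dimethylphenyl group; in this assay compound 2 gives 28400 nM, the higher of the two numbers, and the gap to compound 1 lies beyond the scatter. Compound 3 `Fc1ccccc1N1CCN(Cn2nc(-c3ccc4c(c3)OCCO4)oc2=S)CC1` is not yet measured; it differs from compound 2 by 2-fluorophenyl in place of 2,4-dimethylphenyl on an amine nitrogen in a ring. Among the compounds with values here, no pair of measured compounds differing in one place exists here to set the size of such a step, so the expectation rests on the two values alone. The step of a 1.4-fold lower number from compound 2 to compound 3 (0.15 log units; within the scatter) is expected to be modest, toward a lower number, and possibly within the scatter. Compound 3 is expected to give about 20000 nM, within a range from 7000 nM to 57000 nM.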

Compound 3, half-maximal inhibitory concentration: > 50000 nM
Compound 3 gave a limit, no number; the forecaster's own chance of this, stated with the estimate: 10%; middle value at least 2.5-fold (0.39 log units) from the limit.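

Compound 3 carries a limit of the assay rather than a number: the limit of > 50000 nM in this assay, at which 1 of the 3 values shown sits. Within the data shown here, the change to 2-fluorophenyl in place of 2,4-dimethylphenyl on an amine nitrogen in a ring gives an at least 1.7-fold higher number from compound 2 to compound 3 (0.24 log units; that floor lies within the scatter), the first step at this position that changes one group alone. Going by these compounds, it shows that this swap of one substituted phenyl group for another brought no gain in inhibition, although the floor of the step does not by itself establish a real loss, and its true size stays unknown.

Still open, on these data alone, is whether the step follows the fluorine or the departure of the two methyl groups; a plain phenyl or a 2-methylphenyl group on that nitrogen would separate the two. As far as these compounds go, whether a larger group of another kind, such as a benzyl group, would lower the number also remains open.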